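This account rests on a few compounds, and the source may have more. Where it says the series, first, only, none or still open, it means among the compounds named here.

Compound 1 `COc1ccc(CNc2c(-c3ccccc3O)nc3ccccn23)cc1`: 15 nM
Compound 2 `COc1ccc(CNc2c(-c3ccccc3OC)nc3ccccn23)cc1`: 230 nM

In a functional assay on HeLa cells (Homo sapiens) for cytotoxicity, read by sulforhodamine B assay, with a stated time of 3 days (on this read-out lower numbers stand for stronger inhibition and higher numbers for weaker inhibition), compound 1 has the lower of the two numbers, 15 nM. Compound 3 `COc1ccc(CNc2c(-c3cc([N+](=O)[O-])ccc3O)nc3ccccn23)cc1` differs from it by nitro in place of hydrogen on an aromatic carbon, para to a hydroxy group: nitro in place of hydrogen on an aromatic carbon. Within the data shown here, the only measured step, a 15-fold higher number from compound 1 to compound 2 (1.19 log units; beyond the scatter), is large and comes from methyl in place of hydrogen on an oxygen on an aromatic ring. Among the measured compounds shown here, compound 3 keeps its hydroxy group, and no measured step adds a nitro, which makes that step only a loose guide. A smaller rise is expected here, a 2.7-fold higher number from compound 1 to compound 3 (0.43 log units; beyond the scatter). Compound 3 is estimated at 40 nM, with an expected range of 10 nM to 200 nM.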

Compound 3, half-maximal inhibitory concentration: 210 nM
Beside the measured number, compound 3's estimate is 5.3-fold (0.72 log units) below it; measured number above the stated range.
By their numbers in this assay, from the lowest: compound 1; then compounds 3 and 2 (each within the scatter of the next).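

Adding nitro on the aromatic carbon para to the hydroxy group gives a 14-fold higher number from compound 1 to compound 3 (1.15 log units; beyond the scatter) in this assay. The hydroxy group stays in place in compound 3, so keeping it is not enough to hold the low number of compound 1, and this ring responds to a change at a carbon as well as at the oxygen. Nothing available explains why the number rises. The compounds shown leave open whether this rise belongs to nitro itself or would follow any group on this carbon. Fluorine, methyl or an amine there could separate those two readings.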